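From a Fluorinated Ring to a Hydroxylated One

The source may hold more compounds than are shown below. What is called first, only, known or untested is meant among the compounds shown, and "the series" means these compounds.

Two measured compounds set the scene. Compound 1 `COc1cc(-n2cnc3ccc(-c4cccc(C)c4)cc32)cc(OC)c1OC` gives 3820 nM in a functional assay on A549 cells (Homo sapiens) for antiproliferative activity, read by MTT assay, with a stated time of 72 h (a higher number here means a weaker inhibitor, a lower number a stronger inhibitor), and compound 2 `COc1cc(-n2cnc3ccc(-c4cccc(F)c4)cc32)cc(OC)c1OC` gives 5270 nM in this assay. For the measured compounds named here, the single measured step, a 1.4-fold higher number from compound 1 to compound 2 (0.14 log units; within the scatter), leaves compound 2 with the highest of the two numbers, its nearest neighbour being compound 1 by a margin that lies within the scatter.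

Compound 3 `COc1cc(-n2cnc3ccc(-c4ccc(O)cc4)cc32)cc(OC)c1OC` has not yet been measured. It differs from compound 2 by 4-hydroxyphenyl in place of 3-fluorophenyl on an aromatic carbon. Going by the values given here, the only step that bears on this change is the one from compound 1 to compound 2, which exchanged methyl for fluoro on the same pendant ring and amounted to a 1.4-fold higher number from compound 1 to compound 2 (0.14 log units; within the scatter). That step gives no guide to a hydroxyl group, and it showed that one small exchange on this ring left the number within the scatter. Compound 3 is therefore expected to give about 5000 nM, with a range from 1500 nM to 16000 nM. The estimated step of a 1.1-fold lower number from compound 2 to compound 3 (0.02 log units; within the scatter) is expected to have no clear direction beyond the scatter.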

Compound 3, half-maximal inhibitory concentration: 5090 nM
The estimate for compound 3 lay 1.0-fold (0.01 log units) below the measured number, within the range that was stated.
By their numbers in this assay, from the lowest: compounds 1, 3 and 2 (each within the scatter of the next).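

At this position the change from 3-fluorophenyl to 4-hydroxyphenyl alters two things at once: the group enters with a hydrogen-bond donor and a hydrogen-bond acceptor where the group that leaves has neither, and its substituent stands para rather than meta to a fused ring. Even so, this assay records a 1.0-fold lower number from compound 2 to compound 3 (0.02 log units; within the scatter), and the comparison with the methyl-bearing ring gives a 1.3-fold higher number from compound 1 to compound 3 (0.12 log units; within the scatter), so this larger change stays within the scatter, as the exchange of methyl for fluoro did, and extends that finding from one ring position to a different substituent at another. Across compounds 1, 2 and 3, the three pendant rings therefore cannot be told apart by this measure, and nothing available explains why these exchanges leave the number within the scatter.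

The compounds shown leave open whether the hydroxyl group and its ring position each have an effect that the single combined step conceals, a question that 3-hydroxyphenyl and 4-fluorophenyl would address. They also leave open whether an amine, a carboxylic acid or a longer chain on this ring would move the number beyond the scatter.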